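Amidine series: 4-methylphenyl to 4-bromophenyl

This account rests on a few compounds, and the source may have more. Where it says the series, first, only, none or still open, it means among the compounds named here.

Measured so far in a functional assay on MCF7 cells (Homo sapiens) for cytotoxicity, read by MTT assay, with a stated time of 96 h; a higher number here means a weaker inhibitor, a lower number a stronger inhibitor:
- compound 1 `CCc1ccc(-c2ccc(-c3ccc(C(=N)N)cc3)o2)cc1` gives 3200 nM
- compound 2 `Cn1c(-c2ccccc2)ccc1-c1ccc(C(=N)N)cc1` gives 2700 nM
- compound 3 `Cc1ccc(-c2ccc(-c3ccc(C(=N)N)cc3)o2)cc1` gives 4800 nM

The three numbers lie close together. Compound 3 sits at the upper end of this narrow spread, but the step of a 1.5-fold higher number from compound 1 to compound 3 (0.18 log units; within the scatter) is within the scatter, and the number for compound 2 also lies within the scatter of the number for compound 3, so no order among the three can be read from the data.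

Compound 4 `N=C(N)c1ccc(-c2ccc(-c3ccc(Br)cc3)o2)cc1` differs from compound 3 by bromo in place of methyl on an aromatic carbon. Within the data shown here, the only measured step in this assay, a 1.5-fold higher number from compound 1 to compound 3 (0.18 log units; within the scatter), concerns a saturated chain carbon and was within the scatter; no measured pair shows a bromo entering anywhere, so nothing in the data points to a shift in either direction for this change. The working expectation is therefore a number close to that of compound 3.

Compound 4 is expected to give about 4500 nM in this assay. The range of this estimate for compound 4 runs from 1800 nM to 11000 nM. The step this estimate implies, a 1.1-fold lower number from compound 3 to compound 4 (0.03 log units; within the scatter), is expected to be no larger than the scatter.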

Compound 4, half-maximal inhibitory concentration: 2600 nM
Compound 4: the middle estimate sits 1.7-fold (0.24 log units) above what was measured, and the stated range covers the measured number.
By their numbers in this assay, from the lowest: compounds 4, 2, 1 and 3 (each within the scatter of the next).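

In this assay, bromo on this aromatic carbon, para to a large group, gives a 1.8-fold lower number from compound 3 to compound 4 (0.27 log units; within the scatter), and the same position gives a 1.2-fold lower number from compound 1 to compound 4 (0.09 log units; within the scatter) with bromo in place of ethyl. Among these compounds, a halogen at this position therefore joins methyl and ethyl in a set of numbers that cannot be told apart, and the two steps add the first readings for a change on the aromatic carbon itself. No measurement on hand bears on the reason for this result.

As far as these compounds go, whether any group on this carbon can move the number beyond the scatter remains open, including an amine, a carboxylic acid or a longer chain. Compound 2 differs from the others in more than one place, so the contribution of the core also remains unresolved.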